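A longer acid chain at the assay limit

This account rests on a few compounds, and the source may have more. Where it says the series, first, only, none or still open, it means among the compounds named here.

In a functional assay on RT16 cells (Cricetulus griseus) for inhibition, read by CellTiter-Blue, with a stated time of 96 h, in the presence of a further agent that is not named here (a higher number here means a weaker inhibitor, a lower number a stronger inhibitor), compound 2 (`Nc1nc2[nH]c(CCCCCCCC(=O)O)cc2c(=O)[nH]1`) gives > 1000 nM as its result, which is a limit of the assay and not a number. Compound 1 (`Nc1nc2[nH]c(CCCCCC(=O)O)cc2c(=O)[nH]1`) gives > 1000 nM as its result, and this too is only a limit. Thus the limit of > 1000 nM in this assay, at which 2 of the 2 values shown sit, describes everything measured so far. Compound 3 (`Nc1nc2[nH]c(CCCCCCCCC(=O)O)cc2c(=O)[nH]1`) has carboxymethyl in place of carboxy on a saturated chain carbon, seven bonds along the chain from an aromatic carbon. For the measured compounds named here, one measured step bears on this change, a step that the two limits leave unreadable from compound 1 to compound 2 with 2-carboxyethyl in place of carboxy, and it offers no size to carry forward. No clear change is therefore expected in this assay and a further limit is the likely outcome. The expected move is a step that the limit leaves unreadable from compound 2 to compound 3 and no direction can be read from it. For compound 3 the estimate is 2000 nM (expected range 1000 nM to 4000 nM).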

Compound 3, half-maximal inhibitory concentration: > 100 nM
Compound 3: a limit, no number; the forecaster's own chance of this, stated with the estimate: 90%; the middle value is on the limit's open side.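

In this assay, for the compounds shown here, the results for compound 1, compound 2 and compound 3 are all limits and not numbers, and no step among them can be read. The compounds shown leave open how strongly each inhibits and whether the length of the acid chain matters at all.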